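The source may report more compounds than this note shows. Statements on the series, on what has been measured and on what is new or still open speak of the compounds shown alone.

Measured compounds:
Compound 1, `C=C1C(=O)[C@@]23C(=O)OC[C@]4(C(=O)CCC(C)(C)[C@H]4C=O)[C@@H]2CC[C@@H]1[C@H]3OC(C)=O`: 1390 nM
Compound 2, `C=C1C(=O)[C@@]23C(=O)OC[C@]4(C(=O)CCC(C)(C)[C@H]4C=O)[C@@H]2CC[C@@H]1[C@H]3OC(=O)c1ccccc1`: 1480 nM

Both compounds were tested in a functional assay on K562 cells (Homo sapiens) for cytotoxicity, read by MTT assay, with a stated time of 72 h; a higher number here means a weaker inhibitor, a lower number a stronger inhibitor. Compound 1 and compound 2 share the same core; their two numbers sit within the usual scatter of each other, so neither can be called the stronger inhibitor on these data. Among the measured compounds shown here, the only measured step, a 1.1-fold higher number from compound 1 to compound 2 (0.03 log units; within the scatter), swaps phenyl for methyl on a carbonyl carbon and changes nothing beyond the scatter.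

Compound 3, `C=C1C(=O)[C@@]23C(=O)OC[C@]4(C(=O)CCC(C)(C)[C@H]4C=O)[C@@H]2CC[C@@H]1[C@H]3OC(=O)c1ccc(F)cc1`, has not yet been measured. It differs from compound 1 by 4-fluorophenyl in place of methyl on a carbonyl carbon. The measured step from compound 1 to compound 2 bears directly on this change, since it places a plain phenyl at the same carbonyl carbon and produces no shift beyond the scatter. Adding a fluorine to that phenyl is a smaller change than the methyl-to-phenyl swap already seen. The step from compound 1 to compound 3 is therefore expected to be a 1.1-fold higher number from compound 1 to compound 3 (0.03 log units; within the scatter), with no direction beyond the scatter. Compound 3 is estimated to give 1500 nM in this assay, within a range from 700 nM to 3200 nM.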

Compound 3, half-maximal inhibitory concentration: 2700 nM
Compound 3: the middle estimate sits 1.8-fold (0.26 log units) below what was measured; the range from low to high includes it.
By their numbers in this assay, from the lowest: compounds 1, 2 and 3 (each within the scatter of the next).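

Putting 4-fluorophenyl on this carbonyl carbon gives a 1.9-fold higher number from compound 1 to compound 3 (0.29 log units; within the scatter) in this assay, which extends what was seen with plain phenyl to a phenyl ring carrying a substituent. The new compound also allows a comparison the earlier pair could not offer: fluoro in place of hydrogen on an aromatic carbon gives a 1.8-fold higher number from compound 2 to compound 3 (0.26 log units; within the scatter) and so cannot be said to alter the result. With methyl, phenyl and 4-fluorophenyl all within the scatter of one another at this place, none of compounds 1, 2 and 3 can be called the stronger inhibitor, and the swaps shown here leave the cytotoxicity reading effectively unmoved. Nothing available here offers an explanation for these numbers.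

Still open, on these data alone, is whether a group of a different kind on this carbonyl carbon, such as a carboxylic acid, an amine or a longer chain like butyl, would move the number beyond the scatter. The compounds shown also leave open whether a chloro or methoxy group on the phenyl ring would behave as fluoro does here.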